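A few compounds are considered here, and "the series" means these few. Any claim that something is new, unique, unknown or untested is made for them only; others in the source may bear on it.

Working notes on the hydrazone series.

The series is read in a functional assay on HT-29 cells (Homo sapiens) for cytotoxicity, read by MTT assay, with a stated time of 72 h; on this read-out higher numbers stand for weaker inhibition and lower numbers for stronger inhibition. Compound 1 `COc1ccc(OC)c(/C=N/NC(=O)Nc2ccc(Oc3ccnc(-c4nncn4CCN(C)C)c3)c(F)c2)c1` gives 2070 nM in this assay. Compound 2 `CN(C)CCn1cnnc1-c1cc(Oc2ccc(NC(=O)N/N=C/c3cc(C(C)(C)C)cc(C(C)(C)C)c3O)cc2F)ccn1` gives 680 nM in this assay. Compound 3 `CN(C)CCn1cnnc1-c1cc(Oc2ccc(NC(=O)N/N=C/c3ccc(O)cc3)cc2F)ccn1` gives 1920 nM in this assay, the second highest of the three numbers; compound 1 sits nearest, within the scatter, and compound 2 sits furthest, beyond it.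

Compound 4 `Cc1cc(/C=N/NC(=O)Nc2ccc(Oc3ccnc(-c4nncn4CCN(C)C)c3)c(F)c2)cc(C)c1O` differs from compound 3 in one place: 4-hydroxy-3,5-dimethylphenyl in place of 4-hydroxyphenyl on a carbon with a double bond to nitrogen. Among the compounds with values here, the only single-place step so far, a 1.1-fold lower number from compound 1 to compound 3 (0.03 log units; within the scatter), exchanges the whole aryl group and moves nothing beyond the scatter. Within the data shown here, no measured step adds alkyl groups to the 4-hydroxyphenyl; the lower number of compound 2, which carries a hydroxyl and two tert-butyl groups on its aryl ring, is the nearest point of comparison, but it differs in more than one place.

The step of a 1.6-fold lower number from compound 3 to compound 4 (0.20 log units; within the scatter) is therefore expected to be small, at most a modest move towards lower numbers, and possibly within the scatter. For compound 4 the estimate in this assay is 1200 nM, with a range from 500 nM to 2800 nM.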

Compound 4, half-maximal inhibitory concentration: 1220 nM
Compound 4: middle estimate off by 1.0-fold (0.01 log units), on the low side; the range from low to high includes it.
By their numbers in this assay, from the lowest: compounds 2, 4, 3 and 1 (each within the scatter of the next, the first and the last beyond it).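

In this assay, within the data shown here, the step of a 1.6-fold lower number from compound 3 to compound 4 (0.20 log units; within the scatter) is the first one that keeps the hydroxyl of 4-hydroxyphenyl and adds methyl groups to the ring, and it leaves the number within the scatter. Measured against the 2,5-dimethoxyphenyl group on the same carbon, a 1.7-fold lower number from compound 1 to compound 4 (0.23 log units; within the scatter) is also within the scatter, so the three aryl groups of compounds 1, 3 and 4 are not told apart at this place by this read-out. Nothing measured here bears on the reason for this closeness.

The compounds shown leave open whether an aryl ring carrying an amine or a carboxylic acid in place of the hydroxyl would move the number beyond the scatter. They also leave open what a longer chain in place of the two methyl groups would do.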